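Swapping a Sulfonyl for a Carbamoyl on the Sulfonamide Nitrogen

This account rests on a few compounds, and the source may have more. Where it says the series, first, only, none or still open, it means among the compounds named here.

Compound 2 `CCCCS(=O)(=O)NS(=O)(=O)c1sc(CC(C)C)cc1-c1ccc(Cn2ccnc2)cc1` was tested in an assay on membranes from liver for displacement of a labelled ligand from Type-2 angiotensin II receptor (Rattus norvegicus); a lower number here means a stronger inhibitor, a higher number a weaker inhibitor. In this assay compound 2 gives only a limit, > 10000 nM. Its close relative compound 1 `CC(C)Cc1cc(-c2ccc(Cn3ccnc3)cc2)c(S(=O)(=O)NC(=O)OC(C)(C)C)s1` also gives only a limit in this assay, > 10000 nM. For the measured compounds named here, the single measured step, a step that the two limits leave unreadable from compound 1 to compound 2, therefore has no readable size. Compound 3 `CCCCN(C)C(=O)NS(=O)(=O)c1sc(CC(C)C)cc1-c1ccc(Cn2ccnc2)cc1` differs from compound 2 by butyl(methyl)carbamoyl in place of butylsulfonyl on a sulfonamide nitrogen. Going by the values given here, because both measured values rest at the limit (the limit of > 10000 nM in this assay, at which 2 of the 2 values shown sit), no step of known size bears on this change, and the expected step for compound 3 is a step that the limit leaves unreadable from compound 2 to compound 3. Compound 3 is estimated at 15000 nM, within 3000 nM to 100000 nM, most likely again reported as a limit.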

Compound 3, inhibition constant: > 10000 nM
Compound 3 gave a limit, no number; the forecaster's own chance of this, stated with the estimate: 70%; the middle value is on the limit's open side.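

In this assay compound 3 gives only a limit, > 10000 nM. The steps linking compound 1, compound 2 and compound 3 cannot be read. On these data alone, how strongly any of the three binds, and whether they differ at all, stays open.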